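The compounds below may be only part of what the source reports. "The series", "measured", "known", "first", "only" and "open" are said of these compounds alone.

Measured in a physicochemical assay for solubility, read by HPLC, in simulated intestinal fluid, with a stated time of 16 h, at pH 6.5; on this read-out lower numbers stand for lower solubility and higher numbers for higher solubility:
- Compound 1 `CNC(=O)c1cc(C(=O)N[C@H]2CC[C@H](O)CC2)c([C@@H](C)c2cccc(C)c2)o1`: > 1000 ug/mL
- Compound 2 `CNC(=O)c1cc(C(=O)N[C@H]2CC[C@H](O)CC2)c([C@@H](C)c2ccccc2Cl)o1`: > 1000 ug/mL
- Compound 3 `CNC(=O)c1cc(C(=O)N[C@H]2CC[C@H](O)CC2)c([C@@H](C)c2ccc(C)cc2)o1`: > 1000 ug/mL

All three results are limits of the assay and not numbers: the limit of > 1000 ug/mL in this assay, at which 3 of the 3 values shown sit. Compound 3 therefore has no exact place in this series, and its own result is only the limit > 1000 ug/mL.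

The next compound to be considered is compound 4 `CNC(=O)c1cc(C(=O)N[C@H]2CC[C@H](O)CC2)c([C@@H](C)c2ccccc2)o1`. It differs from compound 3 by hydrogen in place of methyl on an aromatic carbon. In words, hydrogen stands in place of methyl on an aromatic carbon, so 4-methylphenyl becomes phenyl.

Within the data shown here, three measured steps bear on this change, all of them within the same aryl position: a step that the two limits leave unreadable from compound 1 to compound 3, a step that the two limits leave unreadable from compound 2 to compound 3 and a step that the two limits leave unreadable from compound 1 to compound 2. None has a size that can be read, so they give no measured effect for any of these aryl changes. They show only that the three different aryl groups all gave the same limit in this assay. On that basis, no step beyond the scatter is expected, in either direction, and compound 4 may well be reported as a limit again.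

The expected step is a number no higher from compound 3 to compound 4 (the limit leaves the size open). For compound 4 the estimated value is 1000 ug/mL, with an expected range of 500 ug/mL to 1500 ug/mL.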

Compound 4, solubility: 827 ug/mL
Estimate against measurement, compound 4: 1.2-fold (0.08 log units) above, within the range that was stated.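

In this assay compound 4 gives 827 ug/mL, the first result at this aryl position that is a number and not a limit, whereas the steps among compounds 1, 2 and 3 could not be read. Each step to the unsubstituted phenyl now has a floor, all three within the scatter: an at least 1.2-fold lower number from compound 3 to compound 4 (0.08 log units; that floor lies within the scatter), an at least 1.2-fold lower number from compound 2 to compound 4 (0.08 log units; that floor lies within the scatter) and an at least 1.2-fold lower number from compound 1 to compound 4 (0.08 log units; that floor lies within the scatter). These floors show no change beyond the scatter on replacing methyl or chloro with hydrogen, but they do not rule out a larger step, and how much larger stays unread: the limit of > 1000 ug/mL in this assay, at which 3 of the 4 values shown sit.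

Still open, on these data alone, is how the three substituted phenyl compounds rank against one another and how far each lies from compound 4. Also open, as far as these compounds go, is what an amine or a carboxylic acid on the phenyl ring, or a longer chain in place of the methyl on the saturated chain carbon that carries the aryl group, would give in this assay.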